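Series notes: expectation for compound 3 in a cell assay

This account rests on a few compounds, and the source may have more. Where it says the series, first, only, none or still open, it means among the compounds named here.

Compound 1 `COc1cc(Cl)cc(-c2nn(-c3cccc(NC(=O)Nc4ccc(Cl)c(Cl)c4)c3)cc2-c2ccncc2)c1` gives 99% in a functional assay on MDA-MB-435 cells (Homo sapiens) for inhibition, read by sulforhodamine B assay, with a stated time of 48 h, tested at 0.1 uM; a higher number here means a weaker effect of the compound at the concentration tested, a lower number a stronger effect.
Compound 2 `COc1cc(Cl)cc(-c2nn(-c3cccc(NC(=O)Nc4cccc(C(F)(F)F)c4)c3)cc2-c2ccncc2)c1` gives 97% in this assay.

Compound 2 holds the lowest of the two numbers shown, its nearest neighbour being compound 1, and the step of a number 2 percentage points lower from compound 1 to compound 2 (within the scatter) lies within the scatter. Compound 3 `COc1cc(Cl)cc(-c2nn(-c3cccc(NC(=O)c4cccc(C(F)(F)F)c4)c3)cc2-c2ccncc2)c1` differs from compound 2 by 3-(trifluoromethyl)phenyl in place of (3-(trifluoromethyl)phenyl)amino on a carbonyl carbon. Among the compounds with values here, the only measured step concerns the group on the amide-type nitrogen, not the carbonyl carbon, so no step bears directly on this change. No step beyond the scatter is expected in this assay. Compound 3 is expected at 97%, range 85% to 105%, an expected step of no change at the digits printed from compound 2 to compound 3 (within the scatter).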

Compound 3, a percentage reported as activity, at one concentration (the size of the read-out at that concentration, not a potency): 95%
For compound 3 the middle estimate is 2 percentage points above the measured one; measured number inside the range.
By their numbers in this assay, from the lowest: compounds 3, 2 and 1 (each within the scatter of the next).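

Taking the amino nitrogen out of the link on the carbonyl carbon, with the hydrogen-bond donor counted on the leaving group, gives in this assay a number 2 percentage points lower from compound 2 to compound 3 (within the scatter). The same position also tolerates the combined change of group and link, with a number 4 percentage points lower from compound 1 to compound 3 (within the scatter), so neither the amino nitrogen nor the choice between these aryl groups separates the compounds at this concentration. No available evidence accounts for this.

The read-out at one concentration leaves open whether these compounds would differ in the size of their effect at other concentrations. It also leaves open whether a piperidine amide or a carboxylic acid on this carbonyl carbon's aryl group would shift the number.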